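The source may report more compounds than this note shows. Statements on the series, on what has been measured and on what is new or still open speak of the compounds shown alone.

Values in a functional assay on HepG2 cells (Homo sapiens) for antiproliferative activity, read by spectrophotometry, with a stated time of 2 days (a higher number here means a weaker inhibitor of growth, a lower number a stronger inhibitor of growth), both of them limits of the assay:
compound 1 `Cc1ccc(Nc2ncc(C(F)(F)F)c(N3Cc4cccc(N(C)S(C)(=O)=O)c4C3)n2)cc1C`: > 30000 nM
compound 2 `CN(c1cccc2c1CN(c1nc(Nc3cccc(C(F)(F)F)c3)ncc1C(F)(F)F)C2)S(C)(=O)=O`: > 30000 nM

Compound 2 stands only at a limit, > 30000 nM, and gives no number. Compound 1 also stands only at a limit, > 30000 nM. Among the compounds with values here, the reading across the series so far is the limit of > 30000 nM in this assay, at which 2 of the 2 values shown sit.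

Compound 3 `CN(c1cccc2c1CN(c1nc(Nc3cc(Cl)cc(C(F)(F)F)c3)ncc1C(F)(F)F)C2)S(C)(=O)=O` carries chloro in place of hydrogen on an aromatic carbon, meta to a trifluoromethyl group: chloro in place of hydrogen on an aromatic carbon. This turns 3-(trifluoromethyl)phenyl into 3-chloro-5-(trifluoromethyl)phenyl.

Within the data shown here, the one measured step that bears on this change is a step that the two limits leave unreadable from compound 1 to compound 2, with 3-(trifluoromethyl)phenyl in place of 3,4-dimethylphenyl on the same nitrogen. It has no readable size, so no size or direction can be carried over to this assay. No step beyond the scatter is expected, and another limit is the likeliest report.

The estimated step is an at least 1.0-fold lower number from compound 2 to compound 3 (0.02 log units; that floor lies within the scatter).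

For compound 3 the expected value is 28000 nM, with an estimated range from 10000 nM to 45000 nM.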

Compound 3, concentration for 50% growth inhibition: 9900 nM
Beside the measured number, compound 3's estimate is 2.8-fold (0.45 log units) above it, and the stated range ends above it.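

In this assay, within the data shown here, adding chloro on the aromatic carbon meta to a trifluoromethyl group gives the first readable change, an at least 3.0-fold lower number from compound 2 to compound 3 (0.48 log units; beyond the scatter). Set against the 3,4-dimethylphenyl group, the 3-chloro-5-(trifluoromethyl)phenyl group gives a step of the same printed size, an at least 3.0-fold lower number from compound 1 to compound 3 (0.48 log units; beyond the scatter), and both sizes are floors rather than exact differences. The step from 3,4-dimethylphenyl to 3-(trifluoromethyl)phenyl cannot be read, so this place on the ring is the only one where a change shows an effect, and compound 3 alone has left the limit shared by the other two compounds: the limit of > 30000 nM in this assay, at which 2 of the 3 values shown sit.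

The compounds shown leave open whether the gain is specific to chloro or would also follow from another group at this place, such as methoxy, an amine or a carboxylic acid. They also leave open whether chloro needs the trifluoromethyl group to give this step, which a 3-chlorophenyl group on the same nitrogen would address.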